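Demethylation of a Triazole Pair with No Measured Anchor

The source may report more compounds than this note shows. Statements on the series, on what has been measured and on what is new or still open speak of the compounds shown alone.

The series is assessed in a functional assay on MDA-MB-231 cells (Homo sapiens) for cytotoxicity, read by MTT assay; on this read-out higher numbers stand for weaker inhibition and lower numbers for stronger inhibition. Compound 1 `COc1ccc(-n2cc(-c3ccc(OC)c(O)c3)nn2)cc1` reaches only the limit of the assay, with a result of > 10000 nM. Compound 2 `COc1ccc(-c2cn(-c3cc(OC)c(OC)c(OC)c3)nn2)cc1O` likewise ends at the limit, reported as > 10000 nM. Compound 3 `COc1ccc(-c2cn(-c3ccc(OC)c(OC)c3)nn2)cc1OC` has no result reported in this assay, its entry reading "not determined" (no result reported), so it stands nowhere on the numbers shown; the two neighbouring results both sit at the limit of > 10000 nM in this assay, at which 2 of the 3 values shown sit.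

Compound 4 `COc1ccc(-c2cn(-c3ccc(OC)c(OC)c3)nn2)cc1O` differs from compound 3 by hydrogen in place of methyl on an oxygen on an aromatic ring, in words hydrogen in place of methyl on an oxygen on an aromatic ring. Going by the values given here, no measured step between compounds is available to calibrate this change, and with compound 3 itself undetermined there is no direct anchor. Since compound 1 and compound 2 both give only a limit, the expectation for compound 4 in this assay is that it too stays weak, most probably again reported as a limit rather than a number. Compound 4 is therefore estimated at 15000 nM, with a range from 5000 nM to 50000 nM.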

Compound 4, half-maximal inhibitory concentration: > 100 nM
Compound 4 was reported as a limit (the forecaster's own chance of this, stated with the estimate: 70%); the middle value does not contradict the limit.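

Compound 4 gives > 100 nM, which is a limit and not a number. Compound 1 and compound 2 also end at limits, so the steps from each of them to compound 4 cannot be read. The compounds shown leave open what size, if any, the step from methoxy to hydroxy has.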